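The source may report more compounds than this note shows. Statements on the series, on what has been measured and on what is new or still open speak of the compounds shown alone.

In a functional assay on HeLa cells (Homo sapiens) for antiproliferative activity, read by MTT assay, with a stated time of 24 h (a lower number here means a stronger inhibitor, a higher number a weaker inhibitor), compound 1 `Sc1nnc(-c2ccc3c(c2)OCCO3)n1-c1ccccc1` gives 51900 nM and compound 2 `O=[N+]([O-])c1cccc(CSc2nnc(-c3ccc4c(c3)OCCO4)n2-c2ccccc2)c1` gives 45200 nM as its number, which places the two within the scatter of each other. Compound 3 `Cc1ccc(CSc2nnc(-c3ccc4c(c3)OCCO4)n2-c2ccccc2)cc1` differs from compound 2 in one place: 4-methylphenyl in place of 3-nitrophenyl on a saturated chain carbon bound to a sulfur. Within the data shown here, the one measured step, 3-nitrobenzyl in place of hydrogen on a sulfur, was a 1.1-fold lower number from compound 1 to compound 2 (0.06 log units; within the scatter) and so no step beyond the scatter, in either direction, is expected in this assay for this change. The estimated step is a 1.0-fold lower number from compound 2 to compound 3 (0.00 log units; within the scatter) on this evidence. For compound 3 the expected value is 45000 nM with 20000 nM to 95000 nM as the estimated range.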

Compound 3, half-maximal inhibitory concentration: 49700 nM
For compound 3 the middle estimate is 1.1-fold (0.04 log units) below the measured one, and the stated range covers the measured number.
By their numbers in this assay, from the lowest: compounds 2, 3 and 1 (each within the scatter of the next).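

In this assay, 4-methylphenyl in place of 3-nitrophenyl on a saturated chain carbon bound to a sulfur gives a 1.1-fold higher number from compound 2 to compound 3 (0.04 log units; within the scatter), so a second, different aromatic group at this place leaves the number within the scatter. 4-methylbenzyl in place of hydrogen on a sulfur gives a 1.0-fold lower number from compound 1 to compound 3 (0.02 log units; within the scatter), so neither benzyl group shown separates from compound 1 beyond the scatter. No evidence at hand bears on this result. Going by these compounds, whether an amine or a carboxylic acid on that ring, or a longer chain on the sulfur, would move the number beyond the scatter stays open.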